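Moving the hydroxyl on one phenyl ring of compound 2

The source may hold more compounds than are shown below. What is called first, only, known or untested is meant among the compounds shown, and "the series" means these compounds.

Compound 2 `Oc1cccc(-c2cc(-c3ccco3)cc(-c3ccccc3O)n2)c1` gives 90.1% in an assay on isolated protein for inhibition of DNA topoisomerase 1 (Homo sapiens), with a stated time of 30 min, tested at 100 uM (a lower number here means a weaker effect, a higher number a stronger effect of the compound at the concentration tested), the larger of the two numbers shown, while compound 1 `Oc1cccc(-c2cc(-c3cccs3)cc(-c3ccccc3O)n2)c1` gives 83.2%, a step of a number 6.9 percentage points higher from compound 1 to compound 2 (within the scatter). Compound 3 `Oc1ccc(-c2cc(-c3ccco3)cc(-c3cccc(O)c3)n2)cc1` differs from compound 2 by 4-hydroxyphenyl in place of 2-hydroxyphenyl on an aromatic carbon. The only measured step, a number 6.9 percentage points higher from compound 1 to compound 2 (within the scatter), concerns a different group and lies within the scatter, so no shown step bears directly on this change. Compound 3 is therefore expected to show a number 2.1 percentage points lower from compound 2 to compound 3 (within the scatter), no step beyond the scatter. Compound 3 is estimated at 88%, within 72% to 99%.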

Compound 3, a percentage reported as inhibition, at one concentration (the size of the read-out at that concentration, not a potency): 100%
For compound 3 the middle estimate is 12 percentage points below the measured one; the whole stated range lies below it.
By their numbers in this assay, from the lowest: compounds 1, 2 and 3 (each within the scatter of the next, the first and the last beyond it).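

Exchanging 2-hydroxyphenyl for 4-hydroxyphenyl next to the ring nitrogen gives a number 9.9 percentage points higher from compound 2 to compound 3 (within the scatter) in this assay, so this position accepts the hydroxyl in either of these two placements. The earlier compounds shown here all carried 2-hydroxyphenyl here and could not show this. Nothing available explains why the change leaves the read-out within the scatter.

Still open, from the compounds shown here alone, is whether the hydroxyl matters here at all, since a plain phenyl ring does not appear at this position. An amine or a methoxy group on this ring also remains untested among the compounds shown, as does 3-hydroxyphenyl at this position.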